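This account rests on a few compounds, and the source may have more. Where it says the series, first, only, none or still open, it means among the compounds named here.

Series notes. The shared core of compound 1 `Cc1cc(-c2ccccc2)n(/C(N)=N/S(=O)(=O)c2cc(C)c(Cl)cc2SCc2ccc(C(F)(F)F)cc2)n1` carries a benzylsulfanyl arm; the arm is varied across compound 2 `Cc1cc(-c2ccccc2)n(/C(N)=N/S(=O)(=O)c2cc(C)c(Cl)cc2SCc2ccccc2)n1` and compound 3 `Cc1cc(-c2ccccc2)n(/C(N)=N/S(=O)(=O)c2cc(C)c(Cl)cc2SCc2cccc(Cl)c2)n1`. In a functional assay on HeLa cells (Homo sapiens) for cytotoxicity, read by MTT assay, with a stated time of 72 h (on this read-out lower numbers stand for stronger inhibition and higher numbers for weaker inhibition), compound 1 gives 19000 nM, compound 2 gives 5000 nM and compound 3 gives 8000 nM. Compound 3 thus stands second highest of the three numbers: its gap to compound 2 is within the scatter, while from compound 1 to compound 3 the number falls a 2.4-fold lower number from compound 1 to compound 3 (0.38 log units; beyond the scatter).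

Compound 4 `Cc1cc(-c2ccccc2)n(/C(N)=N/S(=O)(=O)c2cc(C)c(Cl)cc2SCc2ccccc2Cl)n1` is the next variant; the change 2-chlorophenyl in place of 3-chlorophenyl on a saturated chain carbon bound to a sulfur moves the chlorine within the same ring. Within the data shown here, the steps that bear on it are a 1.6-fold higher number from compound 2 to compound 3 (0.20 log units; within the scatter) and a 2.4-fold lower number from compound 1 to compound 3 (0.38 log units; beyond the scatter): adding a chlorine to the arm changed nothing beyond the scatter, and the larger swap gave only a modest step. Among the measured compounds shown here, no measured pair shows a chlorine position swap, so in this assay compound 4 is expected near compound 3, with the step of no change at the digits printed from compound 3 to compound 4 (within the scatter) estimated to lie within the scatter. The estimate for compound 4 in this assay is 8000 nM, between 4000 nM and 16000 nM.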

Compound 4, half-maximal inhibitory concentration: 270000 nM
Beside the measured number, compound 4's estimate is 34-fold (1.53 log units) below it; measured number outside the range, above it.
By their numbers in this assay, from the lowest: compounds 2 and 3 (each within the scatter of the next); then compound 1; then compound 4.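

In this assay, the arm is far more sensitive than the earlier modest steps suggested: with 2-chlorophenyl in place of 3-chlorophenyl, the same atoms differently joined give a 34-fold higher number from compound 3 to compound 4 (1.53 log units; beyond the scatter). Chlorine on this arm is therefore not uniformly tolerated; the 3-chlorophenyl arm stayed within the scatter of the plain phenyl arm, whereas the 2-chlorophenyl arm gives a 54-fold higher number from compound 2 to compound 4 (1.73 log units; beyond the scatter). The 4-(trifluoromethyl)phenyl arm no longer marks the high end of the series, since the change to 2-chlorophenyl gives a 14-fold higher number from compound 1 to compound 4 (1.15 log units; beyond the scatter).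

Nothing available explains why this change has so large an effect. Going by these compounds, whether a 2-fluorophenyl, 2-methylphenyl or 2-methoxyphenyl arm would follow 2-chlorophenyl or stay close to the plain phenyl arm of compound 2 remains open.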